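The source may hold more compounds than are shown below. What is called first, only, known or untested is meant among the compounds shown, and "the series" means these compounds.

Of the compounds shown here, three built on one shared core have been tested in a functional assay on A-375 cells (Homo sapiens) for cytotoxicity, read by MTT assay; on this read-out higher numbers stand for weaker inhibition and lower numbers for stronger inhibition. Compound 1 `COc1ccc(/C=C/C(=O)c2ccc(OC)c3c2OC(C)(C)C=C3)cc1OCCO` carries a 2-hydroxyethyl group on an oxygen on an aromatic ring, and in this assay compound 1 gives 9600 nM. Compound 2 `CCCCC(=O)Oc1cc(/C=C/C(=O)c2ccc(OC)c3c2OC(C)(C)C=C3)ccc1OC` carries a butylcarbonyl group in that place, and compound 2 gives 220 nM. Compound 3 `COc1ccc(/C=C/C(=O)c2ccc(OC)c3c2OC(C)(C)C=C3)cc1OC(=O)C1CC1` carries a cyclopropylcarbonyl group there, and compound 3 gives 380 nM. Compound 2 has the lowest of the three numbers, but only the gap to compound 1 is meaningful: that step is a 44-fold lower number from compound 1 to compound 2 (1.64 log units; beyond the scatter), whereas a 1.7-fold higher number from compound 2 to compound 3 (0.24 log units; within the scatter) cannot be told apart from repeat measurement.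

For the measured compounds named here, compound 4 `COc1ccc(/C=C/C(=O)c2ccc(OC)c3c2OC(C)(C)C=C3)cc1OS(=O)(=O)c1ccc(C)cc1` has not yet been measured. (4-methylphenyl)sulfonyl in place of butylcarbonyl on an oxygen on an aromatic ring No measured step swaps one of these carbonyl-bearing groups for a sulfonyl-bearing one, so the closest guides are a 44-fold lower number from compound 1 to compound 2 (1.64 log units; beyond the scatter) and a 25-fold lower number from compound 1 to compound 3 (1.40 log units; beyond the scatter), both large, and both gained by removing the 2-hydroxyethyl group in favour of a carbonyl-bearing group. Compound 4 also lacks the 2-hydroxyethyl group, so most of that gain is expected to be kept, with some uncertainty for the new group. The change is expected to bring a step of a 2.0-fold higher number from compound 2 to compound 4 (0.31 log units; beyond the scatter). Compound 4 is therefore estimated to give about 450 nM, within a range from 120 nM to 2500 nM.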

Compound 4, half-maximal inhibitory concentration: 2400 nM
Compound 4: the middle estimate sits 5.3-fold (0.73 log units) below what was measured; the range from low to high includes it.
By their numbers in this assay, from the lowest: compounds 2 and 3 (each within the scatter of the next); then compound 4; then compound 1.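

In this assay, the oxygen on an aromatic ring does not treat every replacement for 2-hydroxyethyl alike: (4-methylphenyl)sulfonyl still brings a gain (a 4.0-fold lower number from compound 1 to compound 4 (0.60 log units; beyond the scatter)), but a smaller one than the two carbonyl-bearing groups bring, as the steps to compound 4 show (an 11-fold higher number from compound 2 to compound 4 (1.04 log units; beyond the scatter); a 6.3-fold higher number from compound 3 to compound 4 (0.80 log units; beyond the scatter)). Butylcarbonyl and cyclopropylcarbonyl could not be told apart, so the earlier compounds gave no sign that the group on this oxygen could matter much once 2-hydroxyethyl was gone, whereas the (4-methylphenyl)sulfonyl group now shows that it can. No measurement at hand explains why this group falls short of the other two.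

This one change swaps a carbonyl for a sulfonyl and, at the same time, a butyl chain for a six-membered aromatic ring, so the compounds shown leave open which of the two accounts for the difference: a 4-methylbenzoyl group would put the ring on a carbonyl, and a butylsulfonyl group would put the chain on a sulfonyl. Also open, from the compounds shown here alone, is whether a longer carbonyl-bearing chain, such as octanoyl, would match compound 2 and compound 3 or fall towards compound 4.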